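Trading methylsulfonyl for hydrogen on compound 3

The source may hold more compounds than are shown below. What is called first, only, known or untested is meant among the compounds shown, and "the series" means these compounds.

In an ADME assay on HepG2 cells (Homo sapiens) for cytotoxicity, read by MTT assay, with a stated time of 72 h (a higher number here means that more compound is tolerated, a lower number that less compound is tolerated), compound 1 (`O=[N+]([O-])c1cnc2c(Br)cc(Cl)cn12`) gives 16200 nM as a measured number. Compound 2 (`CS(=O)(=O)Cc1nc2c(Br)cc(Cl)cn2c1N`) gives > 125000 nM and that value is a limit. Compound 3 (`CS(=O)(=O)Cc1nc2c(Sc3ccc(Cl)cc3)cc(Cl)cn2c1[N+](=O)[O-]`) stands at > 31200 nM and that value is likewise a limit.

Compound 4 (`Cc1nc2c(Sc3ccc(Cl)cc3)cc(Cl)cn2c1[N+](=O)[O-]`) differs from compound 3 in one place: hydrogen in place of methylsulfonyl on a saturated chain carbon bound to an aromatic carbon with hydrogen in place of methylsulfonyl on a saturated chain carbon bound to an aromatic carbon, so that (methylsulfonyl)methyl becomes methyl. Going by the values given here, no measured pair shows this change on its own, so the size of the step in this assay can only be judged loosely. Both compounds carrying methylsulfonyl give limits. Compound 1, which lacks that group, gives 16200 nM as a number. A moderate downward step is therefore expected, meaning that less compound would be tolerated. The estimated change is an at least 2.2-fold lower number from compound 3 to compound 4 (0.34 log units; beyond the scatter) in this reading. For compound 4 the estimated value is 14000 nM within an expected range from 4500 nM to 45000 nM when measured.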

Compound 4, half-maximal cytotoxic concentration: > 7800 nM
Compound 4: a limit, no number (the forecaster's own chance of this, stated with the estimate: 30%); the middle value does not contradict the limit.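

Compound 3 and compound 4 both give limits, not numbers, and the step between them cannot be read. The compounds shown leave open whether hydrogen in place of methylsulfonyl changes how much compound is tolerated, and in which direction and by how much.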